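Indolyl in place of chlorophenyl on the amide nitrogen

A few compounds are considered here, and "the series" means these few. Any claim that something is new, unique, unknown or untested is made for them only; others in the source may bear on it.

Going by the values given here, compound 2 `COc1cc(/C=C/C(=O)NCC(=O)Nc2cccc(Cl)c2)ccc1O` stands highest of the two numbers so far: in a functional assay, with a stated time of 25 min (a higher number here means a weaker inhibitor, a lower number a stronger inhibitor), compound 2 gives 108000 nM, while compound 1 `COc1cccc(NC(=O)CNC(=O)/C=C/c2ccc(O)c(OC)c2)c1` gives 94300 nM, the two within the scatter. Among the compounds with values here, the one measured step, a 1.1-fold higher number from compound 1 to compound 2 (0.06 log units; within the scatter), concerns the same aryl group on the amide-type nitrogen and stayed within the scatter. Compound 3 `COc1cc(/C=C/C(=O)NCC(=O)Nc2ccc3[nH]ccc3c2)ccc1O` carries 1H-indol-5-yl in place of 3-chlorophenyl on an amide-type nitrogen. Because a 1.1-fold higher number from compound 1 to compound 2 (0.06 log units; within the scatter) was within the scatter, no step beyond the scatter is expected in this assay for a further change at that group. For compound 3 the estimate is 90000 nM, range 40000 nM to 200000 nM. The step thus expected is a 1.2-fold lower number from compound 2 to compound 3 (0.08 log units; within the scatter).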

Compound 3, half-maximal inhibitory concentration: 57400 nM
Beside the measured number, compound 3's estimate is 1.6-fold (0.20 log units) above it; measured number inside the range.
By their numbers in this assay, from the lowest: compounds 3, 1 and 2 (each within the scatter of the next).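

At the amide-type nitrogen, 1H-indol-5-yl in place of 3-chlorophenyl gives a 1.9-fold lower number from compound 2 to compound 3 (0.27 log units; within the scatter) in this assay, and in place of 3-methoxyphenyl it gives a 1.6-fold lower number from compound 1 to compound 3 (0.22 log units; within the scatter). A larger aryl group with a five-membered aromatic ring and a hydrogen-bond donor therefore leaves this number within the scatter, as did the chloro and methoxy exchange. No measurement here explains these small steps. As far as these compounds go, whether an aminophenyl or carboxyphenyl group on this nitrogen would produce a step beyond the scatter stays open. From the compounds shown here alone, the contribution of the indole hydrogen-bond donor also stays open.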